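A few compounds are considered here, and "the series" means these few. Any claim that something is new, unique, unknown or untested is made for them only; others in the source may bear on it.

Among the measured compounds shown here, in a functional assay on CHO cells for agonist activity at Alpha-2C adrenergic receptor (Homo sapiens) (a higher number here means that more compound is needed for the effect, a lower number that less compound is needed), compound 2 `CC(Oc1ccccc1-c1cccnc1)C1=NCCN1` gives 50.1 nM, the lowest of the two numbers so far, while compound 1 `CC(Nc1ccccc1-c1ccccc1)C1=NCCN1` gives 93.3 nM in this assay, a gap that stays within the scatter. Compound 3 `CC(Oc1ccccc1-c1cccs1)C1=NCCN1` differs from compound 2 in one place: thiophen-2-yl in place of pyridin-3-yl on an aromatic carbon. For the measured compounds named here, no measured pair shows this exchange, so no step beyond the scatter is expected in this assay, with a 1.1-fold lower number from compound 2 to compound 3 (0.05 log units; within the scatter) as the estimated move. For compound 3 the expected value in this assay is 45 nM, with a range of 15 nM to 140 nM.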

Compound 3, half-maximal effective concentration: 58.9 nM
Beside the measured number, compound 3's estimate is 1.3-fold (0.12 log units) below it, within the range that was stated.
By their numbers in this assay, from the lowest: compounds 2, 3 and 1 (each within the scatter of the next).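

In this assay, thiophen-2-yl in place of pyridin-3-yl on this aromatic carbon gives a 1.2-fold higher number from compound 2 to compound 3 (0.07 log units; within the scatter), so this read-out does not tell the two aromatic rings apart at this position. Compound 1 and compound 2 differ in more than one place and could not show this. Nothing available accounts for the result. From the compounds shown here alone, what remains open is whether this position also accepts a group other than these aromatic rings, such as a plain phenyl ring carrying an amine, a carboxylic acid or a longer chain.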